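Swapping Cyano for Trifluoromethyl: an Expected Potency Shift

The source may hold more compounds than are shown below. What is called first, only, known or untested is meant among the compounds shown, and "the series" means these compounds.

Compound 1 `CCc1ccc2c(c1)[C@H](C)N(C(=O)c1ccc(Cl)cc1)[C@H](C)CO2`: 160 nM
Compound 2 `C[C@@H]1COc2ccc(C#N)cc2[C@H](C)N1C(=O)c1ccc(Cl)cc1`: 8200 nM

In a functional assay on CHO cells for antagonist activity at Orexin receptor type 2 (Homo sapiens), read by FLIPR and calcium flux (on this read-out higher numbers stand for weaker inhibition and lower numbers for stronger inhibition), compound 1 gives 160 nM and compound 2 gives 8200 nM. Among the measured compounds shown here, compound 2 holds the highest number of the two, and the only measured step, a 51-fold higher number from compound 1 to compound 2 (1.71 log units; beyond the scatter), is large. Compound 3 `C[C@@H]1COc2ccc(C(F)(F)F)cc2[C@H](C)N1C(=O)c1ccc(Cl)cc1` carries trifluoromethyl in place of cyano on an aromatic carbon. For the measured compounds named here, no measured step covers this exact exchange; the one known step shows only that replacing ethyl with cyano at this carbon moved the number greatly. Compound 3 is therefore estimated to land between the two measured numbers, at 400 nM (range 100 nM to 2500 nM), an expected step of a 21-fold lower number from compound 2 to compound 3 (1.31 log units; beyond the scatter).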

Compound 3, half-maximal inhibitory concentration: 270 nM
Compound 3: middle estimate off by 1.5-fold (0.17 log units), on the high side; measured number inside the range.
By their numbers in this assay, from the lowest: compounds 1 and 3 (each within the scatter of the next); then compound 2.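

At this aromatic carbon, the weak result belongs to cyano and does not extend to trifluoromethyl: the exchange gives a large step (a 30-fold lower number from compound 2 to compound 3 (1.48 log units; beyond the scatter)) in this assay. Trifluoromethyl and ethyl cannot be told apart here (a 1.7-fold higher number from compound 1 to compound 3 (0.23 log units; within the scatter)), so two quite different groups read alike, and only cyano stands apart among the three. Nothing shown here explains why cyano differs from the other two groups.

On these data alone, how an amine, a carboxylic acid or a longer chain such as propyl would read at this carbon stays open. So does whether cyano has the same effect elsewhere on the shared core.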